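The source may report more compounds than this note shows. Statements on the series, on what has been measured and on what is new or still open speak of the compounds shown alone.

Of the compounds shown here, two have been measured so far in a functional assay on HeLa cells (Homo sapiens) for cytotoxicity, read by MTT assay, with a stated time of 2 days, tested at 0.1 uM; on this read-out higher numbers stand for a weaker effect at the one concentration tested and lower numbers for a stronger effect. Compound 1, with the structure `CC(=O)c1cc(-c2ccc(F)cc2)cc2cc(-c3ccc(F)cc3)[nH]c12`, gives 90.1% in this assay. Compound 2, with the structure `CC(=O)c1cc(/C=C/c2ccccc2)cc2cc(-c3ccc(F)cc3)[nH]c12`, gives 82.2% in this assay. For the measured compounds named here, compound 2 thus has the lower of the two numbers, but the single step that connects them, a number 7.9 percentage points lower from compound 1 to compound 2 (within the scatter), lies within the scatter, so the two compounds cannot be told apart on these data.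

Compound 3, with the structure `CC(=O)c1cc(/C=C/c2ccc(F)cc2)cc2cc(-c3ccc(F)cc3)[nH]c12`, has not yet been measured. It differs from compound 2 in one place: fluoro in place of hydrogen on an aromatic carbon, on an aromatic carbon of a six-membered aromatic ring of carbon only, para to a large group. Going by the values given here, no measured step exchanges hydrogen for fluoro at this position, so the only guide is the size of the one step that has been seen, which stayed within the scatter. The expected step is therefore a number 1.8 percentage points higher from compound 2 to compound 3 (within the scatter), a change not beyond the scatter. Compound 3 is estimated to give 84% in this assay, with a range from 70% to 96%.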

Compound 3, a percentage reported as activity, at one concentration (the size of the read-out at that concentration, not a potency): 72.6%
The estimate for compound 3 lay 11.4 percentage points above the measured number; the range from low to high includes it.
By their numbers in this assay, from the lowest: compounds 3, 2 and 1 (each within the scatter of the next, the first and the last beyond it).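

Taken alone, placing fluoro on this ring gives a number 9.6 percentage points lower from compound 2 to compound 3 (within the scatter), so in this assay this single exchange cannot be told apart from the ordinary variation between repeated measurements. For the compounds shown here, the longer comparison is clearer: 2-(4-fluorophenyl)ethenyl in place of 4-fluorophenyl gives a number 17.5 percentage points lower from compound 1 to compound 3 (beyond the scatter), the first step here to pass the scatter, which shows that changing this group on the shared core can modestly strengthen the effect at the one concentration tested. Nothing available here explains this difference.

From the compounds shown here alone, what a methoxy group or an amine would do at the same place on the ring remains open, as does the effect of a longer chain in place of the ethenyl link. A reading at a single concentration also leaves open how the compounds would compare across a range of concentrations, so these numbers speak only to a stronger or weaker effect at the one concentration tested.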